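Replacing the piperazine tail in a sphingosine transport series

This account rests on a few compounds, and the source may have more. Where it says the series, first, only, none or still open, it means among the compounds named here.

Compound 2, `CCCCCCCCCCc1ccc(-c2noc(CN3CCNCC3)n2)cc1`, has the lowest number of three related compounds in an assay on HeLa cells for inhibition of sphingosine-1-phosphate transporter SPNS2 (Mus musculus), read by LC-MS, tested at 2 uM (a higher number here means more inhibition at the concentration tested (going by the name of the read-out), a lower number less inhibition), where compound 2 gives 19%. Compound 1, `CCCCCCCCCCc1ccc(-c2noc(CC3CCNC3)n2)cc1`, gives 44% in this assay, and compound 3, `CCCCCCCCCCc1ccc(-c2noc([C@H](CCCCN)NC(C)=O)n2)cc1`, gives 40%. Both steps that touch compound 2 are beyond the scatter: a number 25 percentage points lower from compound 1 to compound 2 (beyond the scatter) and a number 21 percentage points higher from compound 2 to compound 3 (beyond the scatter). The step from compound 1 to compound 3, by contrast, stays within the scatter: a number 4 percentage points lower from compound 1 to compound 3 (within the scatter).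

Compound 4, `CCCCCCCCCCc1ccc(-c2noc(CC(O)CN3CCCCC3)n2)cc1`, is not yet measured. It differs from compound 2 at one place: 1-hydroxy-2-(piperidin-1-yl)ethyl in place of piperazin-1-yl on a saturated chain carbon bound to an aromatic carbon. The group that leaves is the same piperazin-1-yl whose arrival in compound 2 brought a lower number than compound 1, and whose departure towards compound 3 brought a higher number again. Both measured steps around compound 2 thus point upward, by a modest amount, whenever the piperazin-1-yl is exchanged for another group. A similar upward step is therefore expected for compound 4, a number 21 percentage points higher from compound 2 to compound 4 (beyond the scatter), although the incoming 1-hydroxy-2-(piperidin-1-yl)ethyl is unlike either replacement already seen, so the range is kept wide. Compound 4 is estimated to give 40% in this assay, between 20% and 60%.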

Compound 4, a percentage reported as inhibition, at one concentration (the size of the read-out at that concentration, not a potency): 2%
For compound 4 the middle estimate is 38 percentage points above the measured one, and the stated range ends above it.
By their numbers in this assay, from the lowest: compound 4; then compound 2; then compounds 3 and 1 (each within the scatter of the next).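

Exchanging the piperazin-1-yl does not always raise the number in this assay: with 1-hydroxy-2-(piperidin-1-yl)ethyl in its place, the change goes the other way (a number 17 percentage points lower from compound 2 to compound 4 (beyond the scatter)). The new tail also falls well short of the two other tails, with large steps (a number 38 percentage points lower from compound 3 to compound 4 (beyond the scatter)) and (a number 42 percentage points lower from compound 1 to compound 4 (beyond the scatter)), so compound 4 now sits lowest of the four, and this position can move the number in either direction depending on what is attached. The group that leaves and the group that enters have the same counted hydrogen-bond donors and acceptors and the same lack of net charge, so those counts do not separate compound 2 from compound 4, even though both groups also carry a six-membered non-aromatic ring.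

The compounds shown cannot say whether the hydroxyl, the piperidine ring or the longer link accounts for the lower number, and a plain 2-(piperidin-1-yl)ethyl group at the same place would pull these apart. No measurement offered here explains why this tail gives so little inhibition at the concentration tested.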